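The source may report more compounds than this note shows. Statements on the series, on what has been measured and on what is new or still open speak of the compounds shown alone.

Compound 1 `CC/C=C\C[C@H]1C(=O)C=C[C@H]1CC(=O)OCC` gives 20000 nM in a functional assay on RAW264.7 cells (Mus musculus) for inhibition, read by ELISA, with a stated time of 24 h (on this read-out higher numbers stand for an effect only at larger amounts of compound and lower numbers for an effect already at smaller amounts), the low end of the three numbers measured, though all lie within the scatter of one another: compound 2 `CC/C=C\C[C@H]1C(=O)C=C[C@H]1CC(=O)OCCCCC` gives 25000 nM and compound 3 `CC/C=C\C[C@H]1C(=O)C=C[C@H]1CC(=O)OCCOCCO` gives 36000 nM, so that a 1.3-fold higher number from compound 1 to compound 2 (0.10 log units; within the scatter), a 1.8-fold higher number from compound 1 to compound 3 (0.26 log units; within the scatter) and a 1.4-fold higher number from compound 2 to compound 3 (0.16 log units; within the scatter) are each small. Compound 4 `CC/C=C\C[C@H]1C(=O)C=C[C@H]1CC(=O)OC(C)(C)C` differs from compound 1 by tert-butyl in place of ethyl on an oxygen next to a carbonyl group. The measured changes at the oxygen next to a carbonyl group, lengthening or extending the chain, left this assay unchanged beyond the scatter, so no step beyond the scatter is expected in this assay from the branching to tert-butyl. Compound 4 is therefore estimated at 22000 nM, between 10000 nM and 48000 nM, an expected step of a 1.1-fold higher number from compound 1 to compound 4 (0.04 log units; within the scatter).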

Compound 4, half-maximal effective concentration: 20000 nM
For compound 4 the middle estimate is 1.1-fold (0.04 log units) above the measured one; low and high end bracket the measured number.
By their numbers in this assay, from the lowest: compounds 1, 4, 2 and 3 (each within the scatter of the next).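

Within the data shown here, on an oxygen next to a carbonyl group, the earlier compounds carried only unbranched chains, whereas the branched tert-butyl in place of ethyl gives in this assay no change at the digits printed from compound 1 to compound 4 (within the scatter) and so no step beyond the scatter. The other two steps, a 1.3-fold lower number from compound 2 to compound 4 (0.10 log units; within the scatter) and a 1.8-fold lower number from compound 3 to compound 4 (0.26 log units; within the scatter), also stay within the scatter, so branching adds no measurable difference among these four compounds. Nothing available explains this lack of difference.

The compounds leave open whether an amine or a carboxylic acid at the end of a longer chain at this place would give a step beyond the scatter.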